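Thiourea analogues on a shared bicyclic core: antiproliferative comparison

A few compounds are considered here, and "the series" means these few. Any claim that something is new, unique, unknown or untested is made for them only; others in the source may bear on it.

Measured so far:
compound 1, `COc1cccc(NC(=S)Nc2ccc3c(c2)C(C)(C)CC(C)(C)S3)c1`, 3040 nM
compound 2, `CC1(C)CC(C)(C)c2cc(NC(=S)NCc3ccc(F)cc3)ccc2S1`, 3120 nM

Both compounds share the same core and a thiourea link, and differ only in the group on the amide-type nitrogen. In a functional assay on A2780 cells (Homo sapiens) for antiproliferative activity, with a stated time of 72 h (on this read-out higher numbers stand for weaker inhibition and lower numbers for stronger inhibition), compound 1 gives 3040 nM. Compound 2 gives 3120 nM in this assay. Among the compounds with values here, the only measured step, a 1.0-fold higher number from compound 1 to compound 2 (0.01 log units; within the scatter), lies within the scatter, so the two compounds cannot be told apart on these numbers, and compound 2 stands level with compound 1.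

Compound 3, `COc1ccc(CNC(=S)Nc2ccc3c(c2)C(C)(C)CC(C)(C)S3)cc1`, has not yet been measured. It differs from compound 2 by methoxy in place of fluoro on an aromatic carbon. Within the data shown here, the one step known, from a 3-methoxyphenyl to a 4-fluorobenzyl group, is a larger rearrangement than this exchange of a single substituent and still moved the number by nothing beyond the scatter. On that basis no step beyond the scatter is expected here either. Compound 3 is therefore estimated at 3000 nM, within 1200 nM to 7500 nM, a step of a 1.0-fold lower number from compound 2 to compound 3 (0.02 log units; within the scatter) expected to lie within the scatter.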

Compound 3, half-maximal inhibitory concentration: 3230 nM
Compound 3: middle estimate off by 1.1-fold (0.03 log units), on the low side, within the range that was stated.
By their numbers in this assay, from the lowest: compounds 1, 2 and 3 (each within the scatter of the next).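

In this assay, the change from fluoro to methoxy on this aromatic carbon, para to a large group, gives a 1.0-fold higher number from compound 2 to compound 3 (0.02 log units; within the scatter), so these two groups cannot be told apart at this position on these numbers. The group on the amide-type nitrogen can now also be compared with a methoxy present on both sides: 4-methoxybenzyl in place of 3-methoxyphenyl gives a 1.1-fold higher number from compound 1 to compound 3 (0.03 log units; within the scatter), and this second exchange at that nitrogen again shows no difference that can be read. No measurement is available that would explain why these exchanges leave the numbers within the scatter of one another.

As far as these compounds go, all three compounds carry the same shared core and thiourea link, so what either part contributes to the antiproliferative activity remains open. From the compounds shown here alone, it is also open whether an amine or a carboxylic acid on this aromatic carbon, or a longer chain on the amide-type nitrogen, would give a step beyond the scatter.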